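The source may hold more compounds than are shown below. What is called first, only, known or untested is meant among the compounds shown, and "the series" means these compounds.

Compound 1 `C=CCN(Cc1cccs1)C(=O)COc1ccc(C)cc1` is the starting point of this account. In an assay on HEK293 cells for agonist activity at transient receptor potential cation channel subfamily M member 8 (Homo sapiens), read by fluorescence and calcium flux, with a stated time of 15 min (a lower number here means that less compound is needed, a higher number that more compound is needed for the effect), compound 1 gives 20 nM, the lowest of the two numbers reported. Compound 2 `CCN(Cc1ccsc1)C(=O)COc1ccc(C)cc1` differs from compound 1 in several places. In this assay compound 2 gives 88 nM, a higher number that lies beyond the scatter. Compound 3 `CCN(Cc1cc[nH]n1)C(=O)COc1ccc(C)cc1` also differs from compound 1 in several places. In this assay compound 3 is recorded as "not active" (no number reported), so no number stands against it. Among the measured compounds shown here, no two measured compounds differ in a single place, and no single step can be read from the measured set.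

Compound 4 `CCC(C)N(Cc1cccs1)C(=O)COc1ccc(C)cc1` differs from compound 1 in exactly one place: sec-butyl in place of allyl on an amide-type nitrogen. The measured compounds do not isolate the group on the amide-type nitrogen, so nothing in the data fixes the size or direction of this change. The step of a 1.8-fold higher number from compound 1 to compound 4 (0.24 log units; within the scatter) is expected to be small, perhaps a slight rise in the number, and not clearly beyond the scatter. The estimate for compound 4 in this assay is 35 nM, with a range from 8 nM to 150 nM.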

Compound 4, half-maximal effective concentration: 2000 nM
For compound 4 the middle estimate is 57-fold (1.76 log units) below the measured one; the whole stated range lies below it.
By their numbers in this assay, from the lowest: compound 1; then compound 2; then compound 4.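

The group on the amide-type nitrogen carries a large part of the result in this assay: with the rest of compound 1 unchanged, sec-butyl in place of allyl brings a 100-fold higher number from compound 1 to compound 4 (2.00 log units; beyond the scatter). Among the compounds shown here, compounds 1, 2 and 3 differ from one another in several places, so this is the first step in the set that can be tied to this position alone, and it shows that the position does not accept every small carbon group equally. The exchange is also a narrow one, since allyl with 3 heavy atoms and a double bond gives way to sec-butyl with 4 heavy atoms and no double bond, neither group having a ring, a hydrogen-bond donor or acceptor, or a net charge, and no measurement available here accounts for the size of the step.

The compounds shown do not separate the loss of the double bond from the branching or the added carbon, which a straight propyl chain or an isobutyl group on the same nitrogen would help to tell apart. They also leave open how this position would respond to a group bearing an amine or a hydroxyl.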